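This account rests on a few compounds, and the source may have more. Where it says the series, first, only, none or still open, it means among the compounds named here.

- compound 1 `CC(C)=CCC/C(C)=C/CC/C(C)=C/CSC[C@H](NC(=O)CCCCCN1CCN(C)CC1)C(=O)NC1CCCCCC1`: 6200 nM
- compound 2 `CC(C)=CCC/C(C)=C/CC/C(C)=C/CSC[C@H](NC(=O)CCCCCN1CCN(C)CC1)C(=O)NC1CCCCCCC1`: 7500 nM

In a functional assay on BXPC-3 cells (Homo sapiens) for cytotoxicity, read by fluorescence, with a stated time of 48 h (a higher number here means that more compound is needed for the effect, a lower number that less compound is needed), compound 2 gives 7500 nM, which is level with compound 1 once the usual scatter is allowed for. Compound 3 `CC(C)=CCC/C(C)=C/CC/C(C)=C/CSC[C@H](NC(=O)CCCCCN1CCN(C)CC1)C(=O)N1CCCCC1` differs from compound 2 by one change: piperidin-1-yl in place of cyclooctylamino on a carbonyl carbon. Within the data shown here, only one measured step bears on it, a 1.2-fold higher number from compound 1 to compound 2 (0.08 log units; within the scatter), with cyclooctyl in place of cycloheptyl. That step keeps the amide hydrogen, so it only loosely guides a change to piperidin-1-yl. No step beyond the scatter is therefore expected, and the uncertainty is wide. The expected step is a 1.1-fold higher number from compound 2 to compound 3 (0.03 log units; within the scatter). For compound 3 the estimate is 8000 nM, with an expected range of 3500 nM to 18000 nM.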

Compound 3, half-maximal effective concentration: 8800 nM
Beside the measured number, compound 3's estimate is 1.1-fold (0.04 log units) below it; measured number inside the range.
By their numbers in this assay, from the lowest: compounds 1, 2 and 3 (each within the scatter of the next).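

Replacing cyclooctylamino with piperidin-1-yl on the carbonyl carbon removes the amide hydrogen and gives a 1.2-fold higher number from compound 2 to compound 3 (0.07 log units; within the scatter) in this assay, while the same replacement of cycloheptylamino gives a 1.4-fold higher number from compound 1 to compound 3 (0.15 log units; within the scatter). Unlike the earlier step, these changes remove the hydrogen-bond donor, yet compound 3 remains level with compound 1 and compound 2. Nothing available explains this result. From the compounds shown here alone, it remains open whether morpholin-4-yl or an open-chain diethylamino group on this carbonyl carbon would also stay within the scatter.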